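A Biphenyl Amide on the Shared Core of Compound 3

The compounds below may be only part of what the source reports. "The series", "measured", "known", "first", "only" and "open" are said of these compounds alone.

Three amides share one core and differ only in the aryl group on the carbonyl carbon. Compound 1 `COc1ccccc1C(=O)Nc1cccc(-c2oc3cc(-c4ccc(F)cc4)ccc3c(=O)c2O)c1` carries a 2-methoxyphenyl there, and in a functional assay on HeLa cells (Homo sapiens) for antiproliferative activity, read by CCK-8 assay, with a stated time of 72 h (a lower number here means a stronger inhibitor, a higher number a weaker inhibitor), compound 1 gives 14100 nM. Compound 2 `O=C(Nc1cccc(-c2oc3cc(-c4ccc(F)cc4)ccc3c(=O)c2O)c1)c1ccc(Br)cc1` carries a 4-bromophenyl, and in this assay compound 2 gives 9740 nM. Compound 3 `O=C(Nc1cccc(-c2oc3cc(-c4ccc(F)cc4)ccc3c(=O)c2O)c1)c1cc(F)cc(F)c1` carries a 3,5-difluorophenyl, and in this assay compound 3 gives 3380 nM, the lowest of the three numbers: the change a 1.4-fold lower number from compound 1 to compound 2 (0.16 log units; within the scatter) is within the scatter, whereas a 4.2-fold lower number from compound 1 to compound 3 (0.62 log units; beyond the scatter) and a 2.9-fold lower number from compound 2 to compound 3 (0.46 log units; beyond the scatter) go beyond it. Compound 4 `O=C(Nc1cccc(-c2oc3cc(-c4ccc(F)cc4)ccc3c(=O)c2O)c1)c1ccc(-c2ccccc2)cc1` has not been measured; its change from compound 3 is 4-phenylphenyl in place of 3,5-difluorophenyl on a carbonyl carbon. All measured steps swap the aryl group on this carbonyl carbon, and the two that moved the number beyond the scatter both led toward the 3,5-difluorophenyl, which now leaves. Moving away from it is expected to undo part of that gain, so the expected step is a 1.9-fold higher number from compound 3 to compound 4 (0.28 log units; within the scatter), a modest rise. Compound 4 is therefore estimated at 6500 nM, with a range from 2000 nM to 20000 nM.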

Compound 4, half-maximal inhibitory concentration: > 100000 nM
Compound 4: no number, only a limit; the forecaster's own chance of this, stated with the estimate: 10%; middle value at least 15-fold (1.18 log units) away from the limit.
By their numbers in this assay, from the lowest: compound 3; then compounds 2 and 1 (each within the scatter of the next). At a limit, above all of these: compound 4.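

In this assay compound 4 gives no number, only a limit: the limit of > 100000 nM in this assay, at which 1 of the 4 values shown sits. Until now, changing the aryl group on this carbonyl carbon had moved the number only within a narrow span, but 4-phenylphenyl takes it far outside that span, with an at least 29-fold higher number from compound 3 to compound 4 (1.47 log units; beyond the scatter) and an at least 7.0-fold higher number from compound 1 to compound 4 (0.85 log units; beyond the scatter). The closest comparison is the replacement of bromo by phenyl on an aromatic carbon, which turns the 4-bromophenyl of compound 2 into 4-phenylphenyl and gives an at least 10-fold higher number from compound 2 to compound 4 (1.01 log units; beyond the scatter), so a single change at the far end of this aryl group is enough to produce a large loss.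

The compounds shown do not tell how far above the limit compound 4 lies. They also leave open where the number would fall with a 4-methylphenyl, a 4-aminophenyl or a 4-carboxyphenyl on this carbonyl carbon.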